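Phenyl-to-methyl exchange in two bicyclic cores

This account rests on a few compounds, and the source may have more. Where it says the series, first, only, none or still open, it means among the compounds named here.

Measured compounds:
compound 1 `COCCNc1nc(C)cc2c1c(N)nn2C`: 6%
compound 2 `COCCNc1nc(-c2ccccc2)cc2c1c(N)nn2C`: 2%
compound 3 `Cc1cc2nc(-c3ccccc3)nc(N)c2c(=O)[nH]1`: 22%

In an assay on isolated protein for inhibition of MAP kinase-activated protein kinase 2 (Homo sapiens), read by mobility shift assay, tested at 30 uM (on this read-out lower numbers stand for less inhibition and higher numbers for more inhibition at the one concentration tested (going by the name of the read-out)), compound 3 gives the highest of the three numbers; compound 1 and compound 2 both sit well lower. The difference between the core of compound 3 and the core of compound 2 is not broken down here. Going from compound 2 to compound 1 the change is methyl in place of phenyl on an aromatic carbon, and the step is a number 4 percentage points higher from compound 2 to compound 1 (within the scatter). Compound 4 `Cc1nc(N)c2c(=O)[nH]c(C)cc2n1`, not yet measured, carries the same kind of change relative to compound 3, namely (methyl in place of phenyl on an aromatic carbon); here the ring holds 2 nitrogen and the methyl sits between two ring nitrogen atoms, meta to an amino group, rather than next to the ring nitrogen and meta to a (2-methoxyethyl)amino group. Because the earlier step of a number 4 percentage points higher from compound 2 to compound 1 (within the scatter) was small, compound 4 is expected to land near compound 3, with an estimated step of a number 2 percentage points lower from compound 3 to compound 4 (within the scatter). For compound 4 the estimated value in this assay is 20%, between 6% and 34%.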

Compound 4, a percentage reported as inhibition, at one concentration (the size of the read-out at that concentration, not a potency): 18%
Beside the measured number, compound 4's estimate is 2 percentage points above it; measured number inside the range.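

Methyl in place of phenyl on an aromatic carbon has now been read on two cores in this assay, and the new step is a number 4 percentage points lower from compound 3 to compound 4 (within the scatter) on the second core. The two steps agree: the same change on two cores in this assay, a number 4 percentage points higher (within the scatter) from compound 2 to compound 1 and a number 4 percentage points lower (within the scatter) from compound 3 to compound 4, 8 percentage points apart, within the scatter of two such steps. On these two cores the exchange therefore leaves the read-out within the scatter, but this single-concentration read-out gives no potency, and two cores do not show that the same would hold on a third.

Still open, as far as these compounds go, is whether a group other than methyl or phenyl at this carbon, such as an amine or a longer alkyl chain, would move the number beyond the scatter. Also open, from the compounds shown here alone, is which part of the core of compound 3 goes with its higher number.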